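Replacing the decyl chain of compound 2 with a smaller group

The compounds below may be only part of what the source reports. "The series", "measured", "known", "first", "only" and "open" are said of these compounds alone.

Values in a functional assay on HCT-116 cells (Homo sapiens) for antiproliferative activity, read by MTT assay, with a stated time of 72 h; on this read-out lower numbers stand for stronger inhibition and higher numbers for weaker inhibition:
- Compound 1 `O=C1O/C(=C\Cn2cc(-c3cc(C(F)(F)F)cc(C(F)(F)F)c3)nn2)C(OCc2ccccc2)=C1OCc1ccccc1`: > 100000 nM (a limit of the assay, not a number)
- Compound 2 `CCCCCCCCCCc1cn(C[C@H](O)[C@H]2OC(=O)C(OCc3ccccc3)=C2OCc2ccccc2)nn1`: 28800 nM

Compound 3 `C[Si](C)(C)c1cn(C[C@H](O)[C@H]2OC(=O)C(OCc3ccccc3)=C2OCc2ccccc2)nn1` has not yet been measured.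

Of the two measured compounds, only compound 2 has a true number in this assay, so it has no numerical neighbour to be ranked against. Compound 3 keeps the core of compound 2 and changes only at an aromatic carbon of the five-membered aromatic ring with 3 nitrogen: a group of 4 heavy atoms (3 carbon, 1 silicon; no ring) in place of a group of 10 heavy atoms (10 carbon; no ring), on an aromatic carbon. Going by the values given here, no measured pair isolates this change, so the expectation rests on compound 2 at 28800 nM and on the loss of the decyl chain. A moderate shift toward weaker inhibition is expected, an estimated 1.9-fold higher number from compound 2 to compound 3 (0.28 log units; within the scatter). For compound 3 the estimated value is 55000 nM, with an expected range of 22000 nM to 100000 nM.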

Compound 3, half-maximal inhibitory concentration: 31800 nM
Compound 3: the middle estimate sits 1.7-fold (0.24 log units) above what was measured, and the stated range covers the measured number.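

In this assay, the step at this aromatic carbon of the five-membered aromatic ring with 3 nitrogen is a 1.1-fold higher number from compound 2 to compound 3 (0.04 log units; within the scatter). A group of 4 heavy atoms that includes silicon therefore cannot be told apart from the decyl chain on this read-out, even though the two groups differ widely in heavy-atom count. The full decyl chain is thus not required for the level of inhibition seen with compound 2.

On these data alone, it remains open whether an amine, a carboxylic acid or a short chain such as butyl at this carbon would move the value in this assay beyond the scatter. Compound 1 differs from both other compounds in more than one place and its value is a limit of the assay, so it offers no comparison at this position: the limit of > 100000 nM in this assay, at which 1 of the 3 values shown sits.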